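Working notes: 4-fluorophenyl to 2,3-dichlorophenyl

The source may hold more compounds than are shown below. What is called first, only, known or untested is meant among the compounds shown, and "the series" means these compounds.

Measured in a functional assay on PC-3 cells (Homo sapiens) for antiproliferative activity, read by MTT assay, with a stated time of 72 h; on this read-out lower numbers stand for stronger inhibition and higher numbers for weaker inhibition:
- compound 1 `O=C(N/N=C/c1cccc(Cl)c1Cl)Nc1ccc(Oc2ccnc3[nH]ccc23)c(F)c1`: "not active" (no number reported)
- compound 2 `O=C(N/N=C/c1ccc(F)cc1)Nc1ccc(Oc2ccnc3[nH]ccc23)cc1`: 7490 nM

Going by the values given here, compound 2, at 7490 nM, holds the only numerical value so far, so it cannot be ranked against a second number. Compound 1 gives "not active" (no number reported), with no number reported.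

The next compound to be tested is compound 3 `O=C(N/N=C/c1cccc(Cl)c1Cl)Nc1ccc(Oc2ccnc3[nH]ccc23)cc1`. Its change from compound 2 is 2,3-dichlorophenyl in place of 4-fluorophenyl on a carbon with a double bond to nitrogen, with 2,3-dichlorophenyl in place of 4-fluorophenyl on a carbon with a double bond to nitrogen.

Among the compounds with values here, no measured step covers this change. The expectation rests on compound 1, which also carries the 2,3-dichlorophenyl group and gives "not active" (no number reported). A modest move towards weaker inhibition is therefore expected, estimated as a 1.3-fold higher number from compound 2 to compound 3 (0.13 log units; within the scatter). A result without a number is also possible. For compound 3 the expected value is 10000 nM, with an estimated range of 3000 nM to 35000 nM.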

Compound 3, half-maximal inhibitory concentration: "not active" (no number reported)
For compound 3 the study gives words and no number, so the estimate cannot be set against anything.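

In this assay, going by these compounds alone, compound 3 gives "not active" (no number reported) and compound 2 gives 7490 nM so no step between compound 2 and compound 3 can be read. The compounds shown leave open how large the change from 4-fluorophenyl to 2,3-dichlorophenyl is in numbers. No measured evidence bears on this result.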